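Hydroxy for nitro on a chalcone series

The source may hold more compounds than are shown below. What is called first, only, known or untested is meant among the compounds shown, and "the series" means these compounds.

Measured compounds:
compound 1, `COc1ccc(C(=O)/C=C/c2ccc3ccccc3c2)c2c1C=CC(C)(C)O2`, 7650 nM
compound 2, `COc1ccc(C(=O)/C=C/c2cccc([N+](=O)[O-])c2)c2c1C=CC(C)(C)O2`, 9720 nM
compound 3, `COc1ccc(C(=O)/C=C/c2ccc(C(F)(F)F)cc2)c2c1C=CC(C)(C)O2`, > 10000 nM

Of the compounds shown here, three sharing one core have been tested in a functional assay on SK-OV-3 cells (Homo sapiens) for antiproliferative activity, read by MTT assay, with a stated time of 24 h; on this read-out higher numbers stand for weaker inhibition and lower numbers for stronger inhibition. Compound 1 gives 7650 nM. Compound 2 gives 9720 nM, the highest of the two numbers; its nearest neighbour is compound 1, and the two lie within the scatter of each other, so no order between them can be claimed. Compound 3 gives only a limit, > 10000 nM, which is not a number; (the limit of > 10000 nM in this assay, at which 1 of the 3 values shown sits).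

Compound 4, `COc1ccc(C(=O)/C=C/c2cccc(O)c2)c2c1C=CC(C)(C)O2`, has not yet been measured in this assay. It differs from compound 2 in one place: hydroxy in place of nitro on an aromatic carbon. Within the data shown here, no pair of measured compounds shows what such a change does, so there is nothing to lean on but the three values, all of them weak. The step from compound 2 is expected to be small, a 1.1-fold lower number from compound 2 to compound 4 (0.03 log units; within the scatter), in no firm direction. Compound 4 is therefore estimated at 9000 nM, between 3000 nM and 27000 nM.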

Compound 4, half-maximal inhibitory concentration: > 10000 nM
Compound 4: no number, only a limit (the forecaster's own chance of this, stated with the estimate: 35%); middle value at least 1.1-fold (0.04 log units) away from the limit.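

In this assay, compound 4 gives only a limit, > 10000 nM, and not a number. Among these compounds, the change from 3-nitrophenyl to 3-hydroxyphenyl is the first one-place step that can be read in this set, and it comes out as an at least 1.0-fold higher number from compound 2 to compound 4 (0.01 log units; that floor lies within the scatter), so hydroxy at this position brings no sign of stronger inhibition, while the true size of the step stays unknown. The upper end of the test now limits what this series can show: the limit of > 10000 nM in this assay, at which 2 of the 4 values shown sit.

From the compounds shown here alone, whether an amine or a carboxylic acid at this same place on the ring would give a clearly lower number than nitro remains open. Also open, going by these compounds, is whether hydroxy would behave in the same way at another place on that ring.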